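Dropping the methoxy: from compound 2 to compound 3

This account rests on a few compounds, and the source may have more. Where it says the series, first, only, none or still open, it means among the compounds named here.

Measured so far:
- compound 1, `Cc1ccccc1Nc1nnc(Nc2nc(-c3ccc([N+](=O)[O-])cc3)cs2)s1`: 100 mg/kg
- compound 2, `COc1ccc(Nc2nnc(Nc3nc(-c4ccc([N+](=O)[O-])cc4)cs3)s2)cc1`: 30 mg/kg

Both compounds were tested in a functional assay on the whole organism (strain albino) with Mus musculus as the target, in the maximal electroshock model, with a stated time of 0.5 h; on this read-out higher numbers stand for an effect only at larger amounts of compound and lower numbers for an effect already at smaller amounts. Compound 1 gives 100 mg/kg, while compound 2 gives 30 mg/kg, the lowest of the two numbers. For the measured compounds named here, the one measured step, a 3.3-fold lower number from compound 1 to compound 2 (0.52 log units; beyond the scatter), shows that swapping the group on that nitrogen can move the number by a modest amount.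

Compound 3, `O=[N+]([O-])c1ccc(-c2csc(Nc3nnc(Nc4ccccc4)s3)n2)cc1`, has not yet been measured. It differs from compound 2 in one place: hydrogen in place of methoxy on an aromatic carbon. Cut one bond further out, the change reads 4-methoxyphenyl to phenyl.

Going by the values given here, no measured step removes a group from this ring altogether; the step from compound 1 to compound 2 exchanges one substituted phenyl for another and so bears on compound 3 only loosely. Since the methoxy of compound 2 sits on the side that gave the lower number, its loss is expected to cost a little, giving an estimated step of a 1.7-fold higher number from compound 2 to compound 3 (0.22 log units; within the scatter). Compound 3 is therefore expected to give about 50 mg/kg, within a range from 25 mg/kg to 150 mg/kg.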

Compound 3, minimum effective dose: 100 mg/kg
Compound 3: middle estimate off by 2.0-fold (0.30 log units), on the low side; low and high end bracket the measured number.
By their numbers in this assay, from the lowest: compound 2; then compounds 1 and 3 (each within the scatter of the next).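

In this assay, removing the methoxy gives a 3.3-fold higher number from compound 2 to compound 3 (0.52 log units; beyond the scatter), which ties the lower number of compound 2 to this group, para to a large group on the phenyl ring, rather than to the shared core. Compound 3 also separates what the earlier step between compound 1 and compound 2 could not, since that step took away a methyl and added a methoxy at once: hydrogen in place of the methyl gives no change at the digits printed from compound 1 to compound 3 (within the scatter), so among these three compounds only the methoxy comes with a shift beyond the scatter. Nothing available explains how the methoxy produces this difference in the whole animal.

Going by these compounds, it remains open whether the lower number is specific to the methoxy or would also appear with another group at this place, such as an ethoxy, a hydroxyl or an amine. The compounds shown also leave open whether a methoxy would have the same effect elsewhere on the ring, since the only group tested at another place is the methyl of compound 1.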